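Methyl for Trifluoromethyl on the Thiourea Aryl Ring

A few compounds are considered here, and "the series" means these few. Any claim that something is new, unique, unknown or untested is made for them only; others in the source may bear on it.

In a functional assay on HL-60 cells (Homo sapiens) for antiproliferative activity, with a stated time of 24 h (on this read-out higher numbers stand for weaker inhibition and lower numbers for stronger inhibition), compound 3 `Cc1ccccc1C(=O)Nc1sc2c(c1C(N)=O)CCN(C(=S)Nc1ccccc1C(F)(F)F)C2` gives 23200 nM. Compound 1 `Cc1ccccc1NC(=S)N1CCc2c(sc(NC(=O)c3ccccc3Cl)c2C(N)=O)C1` gives 22600 nM and compound 2 `Cc1ccccc1C(=O)Nc1sc2c(c1C(N)=O)CCN(C(=S)Nc1ccccc1Br)C2` gives 45200 nM; both of these numbers sit within the usual scatter of that of compound 3, so no order among the three can be claimed. Compound 4 `Cc1ccccc1NC(=S)N1CCc2c(sc(NC(=O)c3ccccc3C)c2C(N)=O)C1` carries methyl in place of trifluoromethyl on an aromatic carbon. Among the compounds with values here, the only step that touches this position is a 1.9-fold lower number from compound 2 to compound 3 (0.29 log units; within the scatter), a change that stayed within the scatter. Nothing in the three measured compounds therefore points to a shift beyond the scatter for compound 4, and its number in this assay is expected near that of compound 3, as a 1.0-fold lower number from compound 3 to compound 4 (0.00 log units; within the scatter). Compound 4 is accordingly estimated at 23000 nM, in a range from 8000 nM to 65000 nM.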

Compound 4, half-maximal inhibitory concentration: > 50000 nM
Compound 4 ended at the assay's limit (the forecaster's own chance of this, stated with the estimate: 10%); middle value at least 2.1-fold (0.33 log units) from the limit.
By their numbers in this assay, from the lowest: compounds 1, 3 and 2 (each within the scatter of the next). At a limit, above all of these: compound 4.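

In this assay, within the data shown here, 2-methylphenyl in place of 2-(trifluoromethyl)phenyl gives the first step at this position beyond the scatter, an at least 2.1-fold higher number from compound 3 to compound 4 (0.33 log units; beyond the scatter), while the step from bromo stays unresolved, an at least 1.1-fold higher number from compound 2 to compound 4 (0.04 log units; that floor lies within the scatter). Compound 4 gives > 50000 nM, which is a limit of the assay and not a number. Methyl in place of chloro on an aromatic carbon elsewhere in the molecule also moves beyond the scatter, an at least 2.2-fold higher number from compound 1 to compound 4 (0.34 log units; beyond the scatter).

From the compounds shown here alone, how far the true value of compound 4 lies past that limit remains open. So does how an amine or a carboxylic acid on this aromatic carbon would read out.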